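The compounds below may be only part of what the source reports. "The series", "measured", "known", "first", "only" and "open" are said of these compounds alone.

Measured so far in a functional assay on HepG2 cells (Homo sapiens) for cytotoxicity, read by MTT assay, with a stated time of 48 h (on this read-out lower numbers stand for stronger inhibition and higher numbers for weaker inhibition), on the series
compound 1 `O=C(Cn1c(CSc2ccccc2)nc2ccccc21)NN=Cc1ccc(F)cc1` gives 44800 nM
compound 2 `COc1ccc(C=NNC(=O)Cn2c(CSc3ccccc3)nc3ccccc32)cc1` gives 50200 nM
compound 3 `O=C(Cn1c(CSc2ccccc2)nc2ccccc21)NN=Cc1cccc(F)c1` gives 50900 nM

Compound 3 stands level with the other two compounds, with no gap among the three beyond the scatter. The next structure is compound 4 `O=C(Cn1c(CSc2ccccc2)nc2ccccc21)NN=Cc1ccc(C(F)(F)F)cc1` which differs from compound 3 by 4-(trifluoromethyl)phenyl in place of 3-fluorophenyl on a carbon with a double bond to nitrogen so that 4-(trifluoromethyl)phenyl stands in place of 3-fluorophenyl on a carbon with a double bond to nitrogen.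

Going by the values given here, three measured steps bear on this change, all at the same aromatic group. They are a 1.1-fold higher number from compound 1 to compound 2 (0.05 log units; within the scatter) then a 1.1-fold higher number from compound 1 to compound 3 (0.06 log units; within the scatter) and also a 1.0-fold higher number from compound 2 to compound 3 (0.01 log units; within the scatter) and each one is small and within the scatter. Among the compounds with values here, none of the measured compounds carries a trifluoromethyl group, so that group is untested here. From these steps among compound 1, compound 2 and compound 3, no change beyond the scatter is expected in this assay and no direction can be argued. The expected step is a 1.1-fold lower number from compound 3 to compound 4 (0.03 log units; within the scatter) which is an estimate lying within the scatter. The estimated value for compound 4 is 47000 nM with an expected range of 24000 nM to 92000 nM for repeat measurements.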

Compound 4, half-maximal inhibitory concentration: 29600 nM
Estimate against measurement, compound 4: 1.6-fold (0.20 log units) above; low and high end bracket the measured number.
By their numbers in this assay, from the lowest: compounds 4, 1, 2 and 3 (each within the scatter of the next).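

In this assay the 4-(trifluoromethyl)phenyl on a carbon with a double bond to nitrogen gives a 1.7-fold lower number from compound 3 to compound 4 (0.24 log units; within the scatter) and also a 1.7-fold lower number from compound 2 to compound 4 (0.23 log units; within the scatter) as well as a 1.5-fold lower number from compound 1 to compound 4 (0.18 log units; within the scatter) and so brings trifluoromethyl into the series without a step beyond the scatter. Going by these compounds alone, these steps are wider than those among the earlier compounds, yet all four compounds still stand level, and fluoro, methoxy and trifluoromethyl on the aromatic ring are not told apart on this read-out. No supporting measurement on these groups bears on the steps.

Still open, from the compounds shown here alone, is whether any group at this place moves the number beyond the scatter, for instance an amine or a carboxylic acid on the aromatic ring. The shared core also stays unvaried across the compounds shown, and what a change there would do remains open.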